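The compounds below may be only part of what the source reports. "The series", "measured", "known", "first", "only" and "open" are said of these compounds alone.

For the measured compounds named here, compound 1 `Cc1cccc(NC(=O)CN2CCC(c3cccc(F)c3)CC2)c1` is one of two compounds measured in a functional assay on HEK293 cells for agonist activity at D(4) dopamine receptor (Homo sapiens), read by FLIPR (on this read-out lower numbers stand for smaller maximal responses and higher numbers for larger maximal responses), and in that assay compound 1 gives 40%. The other compound, compound 2 `Cc1cccc(Cl)c1NC(=O)CN1CCC(c2ccccn2)CC1`, gives in this assay 70%, so compound 1 holds the lower of the two numbers and compound 2 stands above it by more than the usual scatter. Going by the values given here, compound 2 also differs from compound 1 at more than one place, so the two values show only that the pair sits apart, not which change carries the difference.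

Compound 3 `Cc1cccc(NC(=O)CN2CCC(c3ccccc3C)CC2)c1` has not yet been measured. Against compound 1 it shows one change: 2-methylphenyl in place of 3-fluorophenyl on a saturated ring carbon. Among the compounds with values here, no measured pair shows this exact change, so the size of the step has to be estimated from the one number available. Compound 3 is expected to stay close to compound 1, with a step of a number 5 percentage points higher from compound 1 to compound 3 (within the scatter) in this assay, which lies within the scatter. The estimate for compound 3 in this assay is 45%, with a range from 20% to 75%.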

Compound 3, largest response reached (reported as efficacy), in percent of the reference or control that the assay uses: 43%
For compound 3 the middle estimate is 2 percentage points above the measured one; measured number inside the range.
By their numbers in this assay, from the lowest: compounds 1 and 3 (each within the scatter of the next); then compound 2.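

Exchanging 3-fluorophenyl for 2-methylphenyl on the saturated ring carbon, three ring bonds from the ring nitrogen, gives a number 3 percentage points higher from compound 1 to compound 3 (within the scatter) in this assay, so this read-out does not separate the two compounds. For the compounds shown here, this pair is the first to differ in one place, and it shows directly that this particular exchange of one aryl group for another, each with 7 heavy atoms and one six-membered aromatic ring of carbon only, leaves the maximal response within the scatter. No other measurement bears on why the two values sit together.

Going by these compounds alone, the pair covers only two aryl groups with no hydrogen-bond donors or acceptors and no net charge, so it remains open whether a carboxylic acid, an aminomethyl group or a longer chain such as butyl at this ring carbon would move the response beyond the scatter. This exchange also leaves unresolved which of the several differences between compound 1 and compound 2 accounts for the separation between their values.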